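Swapping the Distal Aryl Ring: A Fluorophenyl Expectation

The source may hold more compounds than are shown below. What is called first, only, known or untested is meant among the compounds shown, and "the series" means these compounds.

Of the compounds shown here, three sharing one core have been measured in a functional assay for agonist activity at G protein-coupled receptor 88 (Homo sapiens), read by HTRF and cAMP accumulation; on this read-out higher numbers stand for an effect only at larger amounts of compound and lower numbers for an effect already at smaller amounts. Compound 1 `CC(C)C[C@H](N)CN(C(=O)[C@@H]1C[C@H]1c1ccccc1)c1ccc(-c2cccs2)cc1` gives 1500 nM, compound 2 `Cc1ccccc1-c1ccc(N(C[C@@H](N)CC(C)C)C(=O)[C@@H]2C[C@H]2c2ccccc2)cc1` gives 3400 nM, and compound 3 `COc1cccc(-c2ccc(N(C[C@@H](N)CC(C)C)C(=O)[C@@H]3C[C@H]3c3ccccc3)cc2)c1` gives 1100 nM. Among the measured compounds shown here, on these numbers compound 3 stands lowest, but its separation from compound 1, a 1.4-fold lower number from compound 1 to compound 3 (0.13 log units; within the scatter), is within the scatter, so only the step of a 3.1-fold lower number from compound 2 to compound 3 (0.49 log units; beyond the scatter) marks a real difference; the step of a 2.3-fold higher number from compound 1 to compound 2 (0.36 log units; beyond the scatter) likewise lies beyond the scatter.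

Compound 4 `CC(C)C[C@H](N)CN(C(=O)[C@@H]1C[C@H]1c1ccccc1)c1ccc(-c2ccccc2F)cc1` differs from compound 3 in one place: 2-fluorophenyl in place of 3-methoxyphenyl on an aromatic carbon. For the measured compounds named here, no measured step introduces 2-fluorophenyl, so the bearing steps are indirect. The step of a 3.1-fold lower number from compound 2 to compound 3 (0.49 log units; beyond the scatter) shows that replacing 2-methylphenyl with 3-methoxyphenyl lowered the number modestly, and a 2.3-fold higher number from compound 1 to compound 2 (0.36 log units; beyond the scatter) shows 2-methylphenyl giving a higher number than thiophen-2-yl. Moving from 3-methoxyphenyl to another substituted phenyl is therefore expected to raise the number modestly, with the change to fluorine not assumed to match the methyl case fully. The expected step is a 1.8-fold higher number from compound 3 to compound 4 (0.26 log units; within the scatter). Compound 4 is accordingly estimated at 2000 nM, within a range from 900 nM to 4500 nM.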

Compound 4, half-maximal effective concentration: 1600 nM
Compound 4: middle estimate off by 1.3-fold (0.10 log units), on the high side, and the stated range covers the measured number.
By their numbers in this assay, from the lowest: compounds 3, 1 and 4 (each within the scatter of the next); then compound 2.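

In this assay, 2-fluorophenyl at this position, para to a large group, cannot be told apart from either 3-methoxyphenyl or thiophen-2-yl: a 1.5-fold higher number from compound 3 to compound 4 (0.16 log units; within the scatter) and a 1.1-fold higher number from compound 1 to compound 4 (0.03 log units; within the scatter) both stay within the scatter. Fluoro in place of methyl does register, with a 2.1-fold lower number from compound 2 to compound 4 (0.33 log units; beyond the scatter), so the gap seen earlier for compound 2 does not extend to every substituted phenyl group, and compound 2 alone stands apart among the four. Nothing measured here accounts for these differences.

The compounds shown leave open how this position responds when a chlorine, a nitrile or an amine takes the place of the fluoro. They also leave open whether any group here would move the number clearly away from the cluster of compound 1, compound 3 and compound 4.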